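Swapping a Formyl Group for a Benzoylethenyl Arm

The source may hold more compounds than are shown below. What is called first, only, known or untested is meant among the compounds shown, and "the series" means these compounds.

Of the compounds shown here, three built on one shared fused core have been tested in a functional assay on C-33-A cells (Homo sapiens) for cytotoxicity, read by sulforhodamine B assay, with a stated time of 48 h; on this read-out lower numbers stand for stronger inhibition and higher numbers for weaker inhibition. Compound 1 `CCC(C)c1cc(/C=C/C(=O)c2ccccc2)cc2cc(C(=O)OC)c(=O)oc12` gives 6280 nM in this assay, and compound 2 `CCOC(=O)c1cc2cc(/C=C/C(=O)c3ccc(C)cc3)cc(C(C)CC)c2oc1=O` gives 3590 nM. Compound 3 `CCOC(=O)c1cc2cc(C=O)cc(C(C)CC)c2oc1=O` gives 64300 nM, the highest of the three numbers: compound 1 lies a good way lower, and compound 2 lower still, with both gaps beyond the usual scatter. Compound 4 `CCOC(=O)c1cc2cc(/C=C/C(=O)c3ccccc3)cc(C(C)CC)c2oc1=O` has not yet been measured. It differs from compound 3 in one place: 2-benzoylethenyl in place of formyl on an aromatic carbon. The same kind of arm is already present in compound 1 and in compound 2, and both of them sit far lower than compound 3 in this assay, so the change is expected to bring a large downward step, well beyond the scatter, landing compound 4 near those two relatives. Compound 4 is expected to give 5000 nM in this assay, within a range from 2000 nM to 13000 nM. That estimate means an expected step of a 13-fold lower number from compound 3 to compound 4 (1.11 log units; beyond the scatter), downward and well beyond the scatter.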

Compound 4, half-maximal inhibitory concentration: 8120 nM
For compound 4 the middle estimate is 1.6-fold (0.21 log units) below the measured one, within the range that was stated.
By their numbers in this assay, from the lowest: compounds 2, 1 and 4 (each within the scatter of the next, the first and the last beyond it); then compound 3.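

Compound 4 gives the first direct measure of this change at this aromatic carbon: in this assay, 2-benzoylethenyl in place of formyl brings a clear drop (a 7.9-fold lower number from compound 3 to compound 4 (0.90 log units; beyond the scatter)). Once the arm is present, a small edit to its aromatic ring has only a modest effect, with hydrogen in place of methyl giving a slight rise (a 2.3-fold higher number from compound 2 to compound 4 (0.35 log units; beyond the scatter)). Methyl in place of hydrogen on the saturated chain carbon bound to an oxygen next to a carbonyl group leaves no readable difference (a 1.3-fold higher number from compound 1 to compound 4 (0.11 log units; within the scatter)).

As far as these compounds go, whether an amine or a carboxylic acid on the arm's aromatic ring, or a longer chain in place of the sec-butyl group, would move the number stays open. Nothing available explains any of these steps.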